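Replacing a sec-butyl amide with methoxymethyl on a hindered core

The compounds below may be only part of what the source reports. "The series", "measured", "known", "first", "only" and "open" are said of these compounds alone.

Measured so far:
Compound 1, `CCC(C)C(=O)Nc1c(C(O)(C(F)(F)F)C(F)(F)F)ccc2ccccc12`, gives 177000 nM in an assay on LtK cells with ATP-sensitive inward rectifier potassium channel 11 (Homo sapiens) as the target; on this read-out lower numbers stand for an effect already at smaller amounts and higher numbers for an effect only at larger amounts of compound.
Compound 2, `O=C(Nc1c(C(O)(C(F)(F)F)C(F)(F)F)ccc2ccccc12)C1CCCC1`, gives 495 nM.
Compound 3, `O=C(CC1CCCC1)Nc1c(C(O)(C(F)(F)F)C(F)(F)F)ccc2ccccc12`, gives 81 nM.

Compound 1 has the highest of the three numbers; the nearest is compound 2, at a 360-fold lower number from compound 1 to compound 2 (2.55 log units; beyond the scatter), and the furthest is compound 3, at a 2200-fold lower number from compound 1 to compound 3 (3.34 log units; beyond the scatter). Compound 4 is `COCC(=O)Nc1c(C(O)(C(F)(F)F)C(F)(F)F)ccc2ccccc12`, and the change from compound 1 is methoxymethyl in place of sec-butyl on a carbonyl carbon. The two measured steps that start from compound 1 both swap the sec-butyl for a ring-bearing group, and both are large; between them a 6.1-fold lower number from compound 2 to compound 3 (0.79 log units; beyond the scatter) adds a modest further step. None of these steps swaps the sec-butyl for a shorter chain with an oxygen, so they only show that this position is sensitive, not in which direction a methoxymethyl will move the number. The expected step of a 1.4-fold higher number from compound 1 to compound 4 (0.15 log units; within the scatter) is therefore small, with a wide spread. Compound 4 is estimated at 250000 nM, within 40000 nM to 1500000 nM.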

Compound 4, half-maximal effective concentration: 213 nM
The estimate for compound 4 lay 1200-fold (3.07 log units) above the measured number; measured number below the stated range.
By their numbers in this assay, from the lowest: compound 3; then compound 4; then compound 2; then compound 1.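

In this assay, the large step (an 830-fold lower number from compound 1 to compound 4 (2.92 log units; beyond the scatter)) shows that a ring is not required for a low number at this position, since methoxymethyl is an open chain. Methoxymethyl also falls among the two ring-bearing groups, with modest steps on either side (a 2.6-fold higher number from compound 3 to compound 4 (0.42 log units; beyond the scatter); a 2.3-fold lower number from compound 2 to compound 4 (0.37 log units; beyond the scatter)), so compound 1 is the outlier among these four amides, and the bearing of the sec-butyl group on the number is sharper than the earlier compounds could show. No measurement offered here explains why this exchange has so large an effect.

From the compounds shown here alone, it remains open whether the oxygen of methoxymethyl matters or whether removing the branched sec-butyl is enough, which a plain propyl group in the same place could test. Going by these compounds, how an amine, a carboxylic acid or a longer ether chain on the carbonyl carbon would behave also stays unknown.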